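Removing the sulfonamide arm from compound 3

This account rests on a few compounds, and the source may have more. Where it says the series, first, only, none or still open, it means among the compounds named here.

Of the compounds shown here, three sharing one core have been measured in a functional assay on A549 cells (Homo sapiens) for antiproliferative activity, read by MTT assay, with a stated time of 72 h; a higher number here means a weaker inhibitor, a lower number a stronger inhibitor. Compound 1 `CC(C)(C)c1cn(C[C@H](O)[C@H]2OC(=O)C(OCc3ccccc3)=C2OCc2ccccc2)nn1` gives 34000 nM, compound 2 `O=C1O[C@H]([C@@H](O)Cn2cc(C3CC3)nn2)C(OCc2ccccc2)=C1OCc1ccccc1` gives 43900 nM, and compound 3 `O=C1O[C@H]([C@@H](O)Cn2cc(CNS(=O)(=O)c3ccc(Cl)cc3)nn2)C(OCc2ccccc2)=C1OCc1ccccc1` gives 2870 nM. Compound 3 stands lowest of the three: a 12-fold lower number from compound 1 to compound 3 (1.07 log units; beyond the scatter) and a 15-fold lower number from compound 2 to compound 3 (1.18 log units; beyond the scatter), while between compound 1 and compound 2 there is only a 1.3-fold higher number from compound 1 to compound 2 (0.11 log units; within the scatter).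

Compound 4 `O=C1O[C@H]([C@@H](O)Cn2cc(CCCCl)nn2)C(OCc2ccccc2)=C1OCc1ccccc1` has not yet been measured. It differs from compound 3 in one place: 2-chloroethyl in place of ((4-chlorophenyl)sulfonyl)amino on a saturated chain carbon bound to an aromatic carbon. In effect the large arm that set compound 3 apart is cut back to a short chain, leaving a small group on the aromatic carbon, as in compound 1 and compound 2.

Among the compounds with values here, the steps that bear on this are the two large ones into compound 3, each of which followed the arrival of that arm. With the arm gone, the number for compound 4 is expected to rise back toward those of compound 1 and compound 2, which both carry small groups, so a step of about an 8.7-fold higher number from compound 3 to compound 4 (0.94 log units; beyond the scatter) is expected. Compound 4 is therefore estimated at 25000 nM, with a likely range from 8000 nM to 70000 nM.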

Compound 4, half-maximal inhibitory concentration: 29000 nM
Compound 4: middle estimate off by 1.2-fold (0.06 log units), on the low side, and the stated range covers the measured number.
By their numbers in this assay, from the lowest: compound 3; then compounds 4, 1 and 2 (each within the scatter of the next).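

In this assay, cutting the arm back gives a 10-fold higher number from compound 3 to compound 4 (1.00 log units; beyond the scatter), so a chain at this place is not enough to keep the low number of compound 3, and neither is a chlorine at the end of that chain. The earlier compounds shown here carried only tert-butyl and cyclopropyl here, whereas 3-chloropropyl now adds an open chain, yet it gives a 1.5-fold lower number from compound 2 to compound 4 (0.18 log units; within the scatter) and a 1.2-fold lower number from compound 1 to compound 4 (0.07 log units; within the scatter). These three groups therefore cannot be told apart in this assay.

The compounds shown do not say which part of the ((4-chlorophenyl)sulfonyl)amino group counts: the sulfonyl amino link, the phenyl ring or its chlorine, as a methylsulfonyl amino group or an unsubstituted phenylsulfonyl amino group on the same carbon would begin to show. Nothing measured here explains why the arm matters.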